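The source may report more compounds than this note shows. Statements on the series, on what has been measured and on what is new or still open speak of the compounds shown alone.

Compound 1 `C#Cc1cccc(Nc2ncnc3cc(OC)c(OCCCCCCCN/C(=N\C#N)Nc4cccnc4)cc23)c1` gives 0.63 nM
Compound 2 `C#Cc1cccc(Nc2ncnc3cc(OC)c(OCCCCCN/C(=N\C#N)Nc4ccncc4)cc23)c1` gives 0.1 nM

In a functional assay on K562 cells (Homo sapiens) for inhibition, read by CCK-8 assay, with a stated time of 72 h (a lower number here means a stronger inhibitor of growth, a higher number a weaker inhibitor of growth), compound 1 stands highest of the two at 0.63 nM, while compound 2 reads 0.1 nM, a gap beyond the scatter. Compound 3 `C#Cc1cccc(Nc2ncnc3cc(OC)c(OCCCCCCCN/C(=N\C#N)Nc4ccncc4)cc23)c1` comes from compound 1 by one change, pyridin-4-yl in place of pyridin-3-yl on an amine nitrogen. Going by the values given here, no measured pair isolates this change, so any forecast is loose. Among the compounds with values here, the only guide is compound 2 at 0.1 nM, which carries the same pyridin-4-yl group as compound 3 but has a different chain. A modest move to a lower number is therefore expected in this assay. The expected change is a 3.2-fold lower number from compound 1 to compound 3 (0.50 log units; beyond the scatter). For compound 3 the estimated value is 0.2 nM, with an expected range from 0.04 nM to 0.8 nM.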

Compound 3, concentration for 50% growth inhibition: 0.21 nM
Estimate against measurement, compound 3: 1.1-fold (0.02 log units) below; measured number inside the range.
By their numbers in this assay, from the lowest: compound 2; then compound 3; then compound 1.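

In this assay, putting pyridin-4-yl in place of pyridin-3-yl on an amine nitrogen gives a 3.0-fold lower number from compound 1 to compound 3 (0.48 log units; beyond the scatter), a modest step beyond the scatter. The two earlier compounds differed in both chain and pyridine group, so they could not show this; the new pair shows that this position responds to the change of pyridine isomer alone, with the chain held constant and the heavy atoms and the counts of hydrogen-bond donors and acceptors in the group unchanged. No measurement at hand accounts for the step.

The compounds shown leave open whether a step of this size would recur with the chain of compound 2. They also leave open how pyridin-2-yl, a plain phenyl or a longer chain would read in this assay.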